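The source may hold more compounds than are shown below. What is called first, only, known or untested is meant among the compounds shown, and "the series" means these compounds.

Compound 1 `CC(C)Oc1nc(N)nc2ncc(-c3ccc(C#N)cc3)nc12`: in a functional assay on cells (T-cell, Homo sapiens) for inhibition (on this read-out higher numbers stand for weaker inhibition and lower numbers for stronger inhibition), compound 1 gives > 10000 nM, which is a limit of the assay rather than a number.
Compound 2 `CC(C)Oc1nc(N)nc2ncc(-c3ccc(C(F)(F)F)cc3)nc12`: in this assay compound 2 gives > 10000 nM, again a limit of the assay.
Among the compounds with values here, compound 3 `CCOc1nc(N)nc2ncc(-c3ccc(C(F)(F)F)cc3)nc12`: in this assay compound 3 gives 10000 nM, the only number among the three measured compounds.

Compound 2 and compound 3 share a core and differ by hydrogen in place of methyl on a saturated chain carbon bound to an oxygen on an aromatic ring and a saturated chain carbon; the step reads a number no higher from compound 2 to compound 3 (the limit leaves the size open). Compound 2 and compound 1 differ by cyano in place of trifluoromethyl on an aromatic carbon, and the step that the two limits leave unreadable from compound 2 to compound 1. Two of the three values sit at the limit of > 10000 nM in this assay, at which 2 of the 3 values shown sit, so neither measured step can be sized.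

Compound 4 `CCOc1nc(N)nc2ncc(-c3ccc(C#N)cc3)nc12` has not yet been measured. It differs from compound 3 by cyano in place of trifluoromethyl on an aromatic carbon, the same change as that from compound 2 to compound 1, made at a place described in identical words. The earlier instance of the change runs from one limit to another and offers no readable size, so it gives nothing to carry over beyond the observation that weak inhibition stayed weak. Compound 3 itself gives 10000 nM in this assay, a number at the edge of what the assay reports. Compound 4 is therefore expected in this assay to fall near 10000 nM, with an expected range from 4000 nM to 30000 nM. The expected step from compound 3 is no change at the digits printed from compound 3 to compound 4 (within the scatter), and a result reported only as a limit is considered likely.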

Compound 4, half-maximal inhibitory concentration: > 10000 nM
Compound 4: no number, only a limit (the forecaster's own chance of this, stated with the estimate: 60%); the middle value sits exactly at the limit.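

Carried from the core of compound 1 to the core of compound 4's neighbour, compound 3, cyano in place of trifluoromethyl leaves inhibition weak in both instances: in this assay compound 4 gives > 10000 nM, which is a limit of the assay and not a number. The new step reads a number no lower from compound 3 to compound 4 (the limit leaves the size open), and neither this step nor the other new step can be sized. This does not show that the change has the same size on both cores, because the values gather at one limit: the limit of > 10000 nM in this assay, at which 3 of the 4 values shown sit.

As far as these compounds go, whether an amine or a carboxylic acid in place of trifluoromethyl would give a readable number in this assay stays open. So does whether a longer chain on the oxygen would do so, and with it any size for this change on either core.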